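Bis-aminomethylbenzene series: removing the chloro from compound 2

A few compounds are considered here, and "the series" means these few. Any claim that something is new, unique, unknown or untested is made for them only; others in the source may bear on it.

Three compounds of the series have been run in a functional assay on MDA-MB-231 cells for antagonist activity at C-X-C chemokine receptor type 4 (Homo sapiens), tested at 10 nM; a higher number here means a stronger effect of the compound at the concentration tested, a lower number a weaker effect. Compound 1 `Clc1nc(Cl)nc(NCc2ccc(CNc3nc(Cl)nc(Cl)n3)cc2)n1` gives 61%. Compound 2 `Clc1cccc(NCc2ccc(CNc3ncccn3)cc2)n1` gives 100%, the highest number of the three; the nearest, compound 1, lies beyond the scatter below it, and compound 3 `Fc1ccc(NCc2ccc(CNc3ccc(F)cn3)cc2)nc1`, with 45%, lies further still. Among the measured compounds shown here, no two of the measured compounds differ in a single place, so no measured step is available for the change now under consideration.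

Compound 4 `c1ccc(NCc2ccc(CNc3ncccn3)cc2)nc1` is the not yet measured analogue of compound 2. The change from compound 2 to compound 4 is hydrogen in place of chloro on an aromatic carbon; cut one bond further out it reads 6-chloropyridin-2-yl to pyridin-2-yl. Nothing in the data isolates the effect of this chloro. The measured range of the series nevertheless suggests room below compound 2, and the working expectation is a moderate loss. The step from compound 2 to compound 4 is expected to be a number 25 percentage points lower from compound 2 to compound 4 (beyond the scatter), a drop somewhat beyond the scatter. Compound 4 is therefore estimated at 75%, in the range 40% to 100%.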

Compound 4, a percentage reported as inhibition, at one concentration (the size of the read-out at that concentration, not a potency): 58%
For compound 4 the middle estimate is 17 percentage points above the measured one, within the range that was stated.
By their numbers in this assay, from the lowest: compound 3; then compounds 4 and 1 (each within the scatter of the next); then compound 2.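

In this assay, among the compounds shown here, the first step that isolates a single change is now available: hydrogen in place of chloro on the aromatic carbon next to the ring nitrogen gives a number 42 percentage points lower from compound 2 to compound 4 (beyond the scatter). What stands at this carbon therefore matters to the read-out at this concentration, although the read-out does not depend on the chloro entirely, as compound 4 still gives 58%. No measurement at hand bears on the reason for the size of this step.

The compounds shown leave open how a methyl, a methoxy or an amine on this same carbon would compare with chloro or hydrogen. Also open, going by these compounds, is whether going from 6-chloropyridin-2-yl to pyridin-2-yl would cost as much with a different group at the other end of the molecule.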